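A few compounds are considered here, and "the series" means these few. Any claim that something is new, unique, unknown or untested is made for them only; others in the source may bear on it.

Within the data shown here, all three compounds measured so far share one core, a hindered phenol carrying two tert-butyl groups, joined through an amide to a piperidine whose ring nitrogen bears a benzyl-type group. Compound 1 `CC(C)(C)c1cc(C(=O)NCCC2CCN(Cc3ccccc3)CC2)cc(C(C)(C)C)c1O` has the amide directly on the ring, compound 2 `CC(C)(C)c1cc(CCC(=O)NCCC2CCN(Cc3ccccc3)CC2)cc(C(C)(C)C)c1O` inserts a two-carbon saturated chain, and compound 3 `Cc1ccccc1CN1CCC(CCNC(=O)/C=C/c2cc(C(C)(C)C)c(O)c(C(C)(C)C)c2)CC1` inserts a two-carbon double bond and carries a 2-methylbenzyl group on the piperidine nitrogen.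

In an assay on isolated protein for inhibition of Amine oxidase [flavin-containing] A (Homo sapiens), read by fluorescence, with stated times of 15 min and 20 min (a higher number here means a weaker inhibitor, a lower number a stronger inhibitor), compound 1 gives 109000 nM, compound 2 gives 94100 nM and compound 3 gives 69300 nM. Compound 3 shows the lowest of the three numbers, but its gaps to compound 2 and to compound 1 both lie within the scatter, so no ordering among them can be claimed.

Compound 4 `CC(C)(C)c1cc(/C=C/C(=O)NCCC2CCN(Cc3ccc(F)cc3F)CC2)cc(C(C)(C)C)c1O` differs from compound 3 in one place: 2,4-difluorophenyl in place of 2-methylphenyl on a saturated chain carbon bound to an amine nitrogen in a ring. Among the measured compounds shown here, no step of this kind has been measured here, so there is nothing to say how the number should move. The step from compound 3 to compound 4 is expected to be a 1.0-fold higher number from compound 3 to compound 4 (0.00 log units; within the scatter), that is, none beyond the scatter. Compound 4 is therefore estimated at 70000 nM, with a range from 30000 nM to 160000 nM.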

Compound 4, half-maximal inhibitory concentration: 70600 nM
Compound 4: middle estimate off by 1.0-fold (0.00 log units), on the low side, and the stated range covers the measured number.
By their numbers in this assay, from the lowest: compounds 3, 4, 2 and 1 (each within the scatter of the next).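

In this assay, among these compounds, the only step read at this place is a 1.0-fold higher number from compound 3 to compound 4 (0.01 log units; within the scatter), so 2,4-difluorophenyl and 2-methylphenyl on a saturated chain carbon bound to an amine nitrogen in a ring cannot be told apart. Earlier compounds offered no comparison that differed in one place, whereas this pair shows that at least one change at this place leaves the number within the scatter. Nothing measured here offers an explanation for this result.

Going by these compounds, it remains open whether a group of another kind, such as a carboxylic acid or an amine on the phenyl ring, would move the number beyond the scatter. Also open, on these data alone, is what a longer chain would do in place of the two-carbon double bond, with 2-methylbenzyl kept.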